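Variation of the aryl group on the aromatic nitrogen

A few compounds are considered here, and "the series" means these few. Any claim that something is new, unique, unknown or untested is made for them only; others in the source may bear on it.

For the measured compounds named here, in a functional assay on A549 cells (Homo sapiens) for cytotoxicity, read by MTT assay, with a stated time of 72 h (on this read-out lower numbers stand for stronger inhibition and higher numbers for weaker inhibition), compound 2 `Cc1ccc(-n2nc(C(=O)Nc3ccc(Oc4ncnc5ccsc45)c(F)c3)c(C)cc2=O)cc1` gives 5890 nM, the highest of the two numbers so far, though within the scatter of its nearest neighbour compound 1 `Cc1cc(=O)n(-c2ccc(Br)cc2F)nc1C(=O)Nc1ccc(Oc2ncnc3ccsc23)c(F)c1`, which gives 2980 nM. Compound 3 `Cc1cc(=O)n(-c2ccc(F)cc2)nc1C(=O)Nc1ccc(Oc2ncnc3ccsc23)c(F)c1` differs from compound 2 by fluoro in place of methyl on an aromatic carbon. Going by the values given here, the only measured step that bears on it is a 2.0-fold higher number from compound 1 to compound 2 (0.30 log units; within the scatter), which also alters the aryl group on the aromatic nitrogen and stays within the scatter, so no step beyond the scatter is expected here, in either direction. Compound 3 is therefore estimated at 4500 nM, range 1500 nM to 13000 nM. This estimate means an expected 1.3-fold lower number from compound 2 to compound 3 (0.12 log units; within the scatter).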

Compound 3, half-maximal inhibitory concentration: 580 nM
The estimate for compound 3 lay 7.8-fold (0.89 log units) above the measured number; the measured number lies below the stated range.
By their numbers in this assay, from the lowest: compound 3; then compounds 1 and 2 (each within the scatter of the next).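

In this assay, the aryl group on the aromatic nitrogen can move the number beyond the scatter, which the earlier pair did not show: fluoro in place of methyl gives a 10-fold lower number from compound 2 to compound 3 (1.01 log units; beyond the scatter) as a large step. 4-Fluorophenyl in place of 4-bromo-2-fluorophenyl gives a 5.1-fold lower number from compound 1 to compound 3 (0.71 log units; beyond the scatter) as a modest step, so the two changes on this aryl group differ in size. No supporting evidence bears on these steps.

As far as these compounds go, what chloro, methoxy or an amine would give in that para place remains open. From the compounds shown here alone, whether the effect of fluoro carries over to other cores also remains open.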